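The source may hold more compounds than are shown below. What is called first, only, known or untested is meant among the compounds shown, and "the series" means these compounds.

Compound 2 `C[n+]1ccn(COCCC[Si](C)(C)C)c1/C=N/O` stands highest of the two compounds measured in a physicochemical assay for lipophilicity; a higher number here means a more lipophilic compound, a lower number a more polar compound: compound 2 gives 0.43, while compound 1 `C[n+]1ccn(COCC[Si](C)(C)C)c1/C=N/O` gives -0.34, and the step of a number 0.77 log units higher from compound 1 to compound 2 (beyond the scatter) lies beyond the scatter. The next compound, compound 3 `C[n+]1ccn(COCCCCCl)c1/C=N/O`, differs from compound 2 in one place: a group of 2 heavy atoms (1 carbon, 1 chlorine; no ring) in place of a group of 4 heavy atoms (3 carbon, 1 silicon; no ring), on a saturated chain carbon, three bonds along the chain from an oxygen on a saturated carbon. Among the measured compounds shown here, only one measured step exists, and it concerns a different change at a different place on the chain, so it bears on the present step only loosely; it shows that one added chain atom was enough to move this assay by a modest amount. For the measured compounds named here, no measured step exchanges a silicon-bearing group for a chlorine-bearing one. Compound 3 is nevertheless expected to give a lower number than compound 2. In this assay compound 3 is estimated at -0.6, within -1.2 to 0. The expected step of a number 1.03 log units lower from compound 2 to compound 3 (beyond the scatter) is thus expected to lie beyond the scatter.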

Compound 3, distribution coefficient: -1.47
Estimate against measurement, compound 3: 0.87 log units above; the whole stated range lies above it.
By their numbers in this assay, from the lowest: compound 3; then compound 1; then compound 2.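

Among the compounds shown here, this exchange, chloromethyl in place of the group of 4 heavy atoms (3 carbon, 1 silicon), is the first to replace a silicon-bearing chain end with a chlorine-bearing one, and in this assay it gives a number 1.90 log units lower from compound 2 to compound 3 (beyond the scatter) as a large step, where the earlier change on this chain was modest. The chlorine-bearing compound also falls well under the shorter silicon-bearing compound, with a number 1.13 log units lower from compound 1 to compound 3 (beyond the scatter) also large and beyond the scatter, so that compound 3 now sits lowest of the series. No independent measurement bears on why the number moves this far.

The compounds shown leave open whether the fall follows the loss of silicon or the arrival of chlorine. On these data alone, a plain butyl chain at this place would separate the two, and how an amine or a hydroxyl there would compare also remains open.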